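This account rests on a few compounds, and the source may have more. Where it says the series, first, only, none or still open, it means among the compounds named here.

Measured in a functional assay on Jurkat cells (Homo sapiens) for antiproliferative activity, read by MTT assay, with a stated time of 72 h; a higher number here means a weaker inhibitor, a lower number a stronger inhibitor:
Compound 1 `CNc1nc(-c2cc(OC)c(OC)c(OC)c2)c(-c2ccc3ccccc3c2)s1`: 51.1 nM
Compound 2 `COc1cc(-c2nc(N(C)C)sc2-c2ccc(C(F)(F)F)cc2)cc(OC)c1OC`: > 10000 nM (a limit)
Compound 3 `COc1ccc(-c2sc(N(C)C)nc2-c2cc(OC)c(OC)c(OC)c2)cc1`: 7600 nM

Compound 1 has the lower of the two actual numbers, and its gap to compound 3 lies beyond the scatter. The entry for compound 2 is a limit of the assay, not a number.

Compound 4 `COc1cc(-c2nc(C)sc2-c2ccc3ccccc3c2)cc(OC)c1OC` differs from compound 1 by methyl in place of methylamino on an aromatic carbon. Among the compounds with values here, no measured step covers this change. The only one, an at least 1.3-fold lower number from compound 2 to compound 3 (0.11 log units; that floor lies within the scatter), is methoxy in place of trifluoromethyl, a different change, so it offers no guide to size. Compounds 2 and 3 both differ from compound 1 in more than one place.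

Since compound 1 already sits at 51.1 nM, the lowest number here, the change is expected to raise the number in this assay by a step beyond the scatter, although this rests on judgement. The expected shift is a 16-fold higher number from compound 1 to compound 4 (1.19 log units; beyond the scatter). For compound 4 the estimated value is 800 nM, with an expected range of 100 nM to 6000 nM.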

Compound 4, half-maximal inhibitory concentration: 48.6 nM
Estimate against measurement, compound 4: 16-fold (1.22 log units) above; the measured number lies below the stated range.
By their numbers in this assay, from the lowest: compounds 4 and 1 (each within the scatter of the next); then compound 3. At a limit, above all of these: compound 2.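

In this assay, replacing methylamino with methyl on the core of compound 1 gives a 1.1-fold lower number from compound 1 to compound 4 (0.02 log units; within the scatter) and leaves the number in the low range set by compound 1. The earlier compounds shown here held no step at this position, on an aromatic carbon next to the ring nitrogen and next to the ring sulfur. This single pair shows that, with the rest of compound 1 held fixed, the hydrogen-bond donor and hydrogen-bond acceptor counted in methylamino can be lost with no change beyond the scatter.

On these data alone, how a carboxylic acid, a hydroxyl group, a longer chain or a bare hydrogen would read at this position remains open, as does whether the same change would behave alike on another core. Nothing in the data at hand bears on the cause of this result.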